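The source may report more compounds than this note shows. Statements on the series, on what has been measured and on what is new or still open speak of the compounds shown alone.

Working notes on the series. Compound 1 `CCC1(CCCCN2CCN(c3cccc(Cl)c3)CC2)C(=O)Nc2ccccc21` and compound 2 `CCC1(CCCCN2CCN(c3cccc(Cl)c3)CC2)C(=O)Nc2cc(F)ccc21` sit on one core; compound 3 `O=C1Nc2ccc(F)cc2C1CCCCN1CCN(c2cccc(Cl)c2)CC1` and compound 4 `O=C1Nc2ccccc2C1CCCCN1CCN(c2cccc(Cl)c2)CC1` sit on another, and the difference between the two cores is not broken down here. In an assay on CHO cells for displacement of a labelled ligand from 5-hydroxytryptamine receptor 7 (Homo sapiens) (on this read-out lower numbers stand for stronger inhibition and higher numbers for weaker inhibition), compound 1 gives 0.41 nM and compound 2 gives 0.67 nM. In this assay compound 3 gives 1.96 nM, the highest of the three numbers, with both of its gaps to the other two beyond the scatter. The change from compound 2 to compound 1 is hydrogen in place of fluoro on an aromatic carbon and produced a 1.6-fold lower number from compound 2 to compound 1 (0.21 log units; within the scatter). The change from compound 3 to compound 4 is hydrogen in place of fluoro on an aromatic carbon; its place is described in the same words, so it counts as the same change, occurring twice among the compounds shown, once measured and once not. Because a 1.6-fold lower number from compound 2 to compound 1 (0.21 log units; within the scatter) lies within the scatter, a step of similar size is expected in this assay, a 1.6-fold lower number from compound 3 to compound 4 (0.21 log units; within the scatter), resting on that single measured instance. Compound 4 is accordingly estimated at about 1.2 nM in this assay, expected to fall between 0.5 nM and 3 nM.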

Compound 4, inhibition constant: 0.49 nM
Compound 4: the middle estimate sits 2.4-fold (0.39 log units) above what was measured; measured number outside the range, below it.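

Set side by side in this assay, the two instances of hydrogen in place of fluoro cannot be told apart: the same change on two cores in this assay, a 1.6-fold lower number (0.21 log units; within the scatter) from compound 2 to compound 1 and a 4.0-fold lower number (0.60 log units; beyond the scatter) from compound 3 to compound 4, 2.4-fold (0.39 log units) apart, within the scatter of two such steps. The new step, a 4.0-fold lower number from compound 3 to compound 4 (0.60 log units; beyond the scatter), runs in the same direction as the earlier one, so on these two cores the change carries over in direction, but two instances do not fix its size on a further core, and only this one lies beyond the scatter. Hydrogen in place of ethyl on a saturated ring carbon gives a 1.2-fold higher number from compound 1 to compound 4 (0.08 log units; within the scatter), which shows that, without fluoro, the ethyl group makes no readable difference, and it does not show what ethyl does when fluoro is present.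

Still open, going by these compounds, is whether methoxy or a nitrile in place of fluoro on that aromatic carbon would move the number in the same direction on both cores. Also open, on these data alone, is whether a longer chain, such as propyl in place of ethyl, would leave the number as close to that of compound 4.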